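The source may hold more compounds than are shown below. What is called first, only, known or untested is meant among the compounds shown, and "the series" means these compounds.

Measured compounds:
Compound 1, `COc1ccc(/C=C/C(=O)NCCCC(C)Nc2cc(OC)cc3cccnc23)cc1`: in an ADME assay on L6 cells (Rattus norvegicus) for cytotoxicity, read by resazurin assay, with a stated time of 70 h (on this read-out higher numbers stand for weaker inhibition and lower numbers for stronger inhibition), compound 1 gives > 240000 nM.
Compound 2, `COc1cc(NC(C)CCCNC(=O)Nc2ccc(Cl)c(C(F)(F)F)c2)c2ncccc2c1`: in this assay compound 2 gives "not determined" (no result reported).

The value of compound 1 is a limit of this assay and not a number, as the limit of > 240000 nM in this assay, at which 1 of the 2 values shown sits, shows. Compound 2 therefore stands without a number of its own in this assay; the only figure shown among the two is that limit.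

Compound 3, `COc1cc(NC(C)CCCNC(=O)NNC(=O)Nc2ccc(Br)cc2)c2ncccc2c1`, differs from compound 2 in one place: ((4-bromophenyl)carbamoyl)amino in place of 4-chloro-3-(trifluoromethyl)phenyl on an amide-type nitrogen. No measured step between two compounds is available here, so the size of the step from compound 2 to compound 3 cannot be read from a comparison, and the one result shown is a limit rather than a number. With only that to go on, the step is expected to be small, with no clear direction beyond the scatter, and the value for compound 3 is expected to sit high, close to where compound 1 stands.

For compound 3 in this assay the estimated value is 150000 nM, with an expected range from 30000 nM to 300000 nM.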

Compound 3, half-maximal inhibitory concentration: 38700 nM
Estimate against measurement, compound 3: 3.9-fold (0.59 log units) above; measured number inside the range.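

No step can be read here: compound 2 has no reported result in this assay and so compound 3 with its 38700 nM has no partner for comparison. What replacing 4-chloro-3-(trifluoromethyl)phenyl with ((4-bromophenyl)carbamoyl)amino does to this read-out stays open, and nothing shown accounts for the value of compound 3.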